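Cyano in place of acetyl on a compound with the lowest number in this assay

The compounds below may be only part of what the source reports. "The series", "measured", "known", "first", "only" and "open" are said of these compounds alone.

Compound 2 `CC(=O)c1cc(=O)oc2cc(OCc3cccc(Cl)c3)ccc12` sits at the bottom of the two numbers measured in an assay on isolated protein (strain Sprague-Dawley) for inhibition of Amine oxidase [flavin-containing] A (Rattus norvegicus), read by spectrophotometry, with a stated time of 5 min, tested at 10 uM (a higher number here means more inhibition at the concentration tested (going by the name of the read-out), a lower number less inhibition), giving 0%; compound 1 `CN(C)C(=O)COc1cc(=O)oc2cc(OCc3cccc(Cl)c3)ccc12` gives 10%, and the step of a number 10 percentage points lower from compound 1 to compound 2 (within the scatter) lies within the scatter. Compound 3 `N#Cc1cc(=O)oc2cc(OCc3cccc(Cl)c3)ccc12` differs from compound 2 by cyano in place of acetyl on an aromatic carbon. Going by the values given here, only that one measured step bears on this change, and it shows that exchanging the group on this carbon left the read-out in this assay unchanged beyond the scatter. A similar outcome is expected here: the estimated step of a number 4 percentage points higher from compound 2 to compound 3 (within the scatter) is nothing beyond the scatter. Compound 3 is therefore expected to give about 4% in this assay, within a range of -8% to 20%.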

Compound 3, a percentage reported as inhibition, at one concentration (the size of the read-out at that concentration, not a potency): 23%
Estimate against measurement, compound 3: 19 percentage points below; the measured number lies above the stated range.
By their numbers in this assay, from the lowest: compounds 2 and 1 (each within the scatter of the next); then compound 3.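

At this aromatic carbon, opposite the ring oxygen, the choice of group does change the number in this assay once cyano enters. Cyano in place of acetyl gives a number 23 percentage points higher from compound 2 to compound 3 (beyond the scatter) and cyano in place of (dimethylcarbamoyl)methoxy gives a number 13 percentage points higher from compound 1 to compound 3 (beyond the scatter), both modest, whereas the step between the two earlier groups stayed within the scatter. Nothing measured here gives a reason for this rise.

Going by these compounds, whether an amine, a carboxylic acid or a longer chain on this carbon would raise the number further remains open. So does whether cyano would give a similar step on a different core.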